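The source may report more compounds than this note shows. Statements on the series, on what has been measured and on what is new or still open speak of the compounds shown alone.

Compound 1 `COc1ccc(C(=O)CC2CC(=O)N(c3ccc(S(N)(=O)=O)cc3)C2=O)cc1` gives 4740 nM in an assay on cells (1-87 tumor cell line) for inhibition of Polyunsaturated fatty acid 5-lipoxygenase (Homo sapiens), with a stated time of 5 min (a lower number here means a stronger inhibitor, a higher number a weaker inhibitor), the lowest of the three numbers recorded. Compound 2 `NS(=O)(=O)c1ccc(N2C(=O)CC(C3CCCCCC3=O)C2=O)cc1` gives 16200 nM in this assay, a gap beyond the scatter, and compound 3 `O=C1CCOCC1C1CC(=O)N(c2ccccc2)C1=O` gives 26800 nM, further still. Compound 4 `Cc1ccc(C(=O)CC2CC(=O)N(c3ccc(S(N)(=O)=O)cc3)C2=O)cc1` differs from compound 1 in one place: methyl in place of methoxy on an aromatic carbon. Going by the values given here, no pair of measured compounds shows this exchange, so no step is known for it. Compound 4 is expected to sit close to compound 1, the step from a 1.1-fold higher number from compound 1 to compound 4 (0.02 log units; within the scatter) being estimated as small and not clearly beyond the scatter in either direction. On that basis compound 4 is estimated at 5000 nM in this assay, with a range from 2000 nM to 12000 nM.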

Compound 4, half-maximal inhibitory concentration: 860 nM
Compound 4: the middle estimate sits 5.8-fold (0.76 log units) above what was measured; the whole stated range lies above it.
By their numbers in this assay, from the lowest: compound 4; then compound 1; then compounds 2 and 3 (each within the scatter of the next).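

Putting methyl in place of methoxy gives a 5.5-fold lower number from compound 1 to compound 4 (0.74 log units; beyond the scatter) in this assay. Going by these compounds alone, this is the first sign that the group on this aromatic carbon, para to a large group, affects the number in this assay, since no earlier pair differed in one place. No measurement offered here explains the change.

The compounds shown leave open whether the gain comes from losing the oxygen or from having the methyl. They also do not show how a bare hydrogen, a chlorine, an ethyl group or an amine would fare at this position.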